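Fluoro in place of nitro on compound 3

The source may report more compounds than this note shows. Statements on the series, on what has been measured and on what is new or still open speak of the compounds shown alone.

In a functional assay on HL-60 cells (Homo sapiens) for inhibition, read by CCK-8 assay, with a stated time of 48 h, tested at 20 uM (on this read-out higher numbers stand for more inhibition of growth at the one concentration tested and lower numbers for less inhibition of growth), compound 3 (`N#C/C(=C\c1ccccc1OS(=O)(=O)c1ccc([N+](=O)[O-])cc1)C(=O)Nc1nnc(Cc2cccc3ccccc23)s1`) gives 18% and sits within the scatter of compound 1 (`N#C/C(=C\c1ccccc1OS(=O)(=O)c1ccc([N+](=O)[O-])cc1)C(=O)Nc1nnc(-c2cccs2)s1`), at 23% here, and of compound 2 (`COc1ccc(Cc2nnc(NC(=O)/C(C#N)=C/c3ccccc3OS(=O)(=O)c3ccc(F)cc3)s2)cc1`). Compound 4 (`N#C/C(=C\c1ccccc1OS(=O)(=O)c1ccc(F)cc1)C(=O)Nc1nnc(Cc2cccc3ccccc23)s1`) carries fluoro in place of nitro on an aromatic carbon, para to a large group (fluoro in place of nitro on an aromatic carbon). Among the measured compounds shown here, no measured step covers this exchange. For the measured compounds named here, the only measured step is a number 5 percentage points lower from compound 1 to compound 3 (within the scatter) and it lies elsewhere in the structure. Compound 2 already holds (4-fluorophenyl)sulfonyl, and its 25% falls within the scatter of the two nitro compounds. The expected result in this assay is therefore a number 4 percentage points higher from compound 3 to compound 4 (within the scatter) with no clear direction. Compound 4 is estimated at 22% (expected range 12% to 33%).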

Compound 4, percent growth inhibition at one concentration: 12%
Compound 4: the middle estimate sits 10 percentage points above what was measured, within the range that was stated.
By their numbers in this assay, from the lowest: compounds 4, 3, 1 and 2 (each within the scatter of the next, the first and the last beyond it).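

In this assay the exchange of (4-nitrophenyl)sulfonyl for (4-fluorophenyl)sulfonyl, now read directly, gives a number 6 percentage points lower from compound 3 to compound 4 (within the scatter) and so does not separate the two compounds. Among the compounds shown here, with (4-fluorophenyl)sulfonyl held fixed, naphthalen-1-yl in place of 4-methoxyphenyl gives a number 13 percentage points lower from compound 2 to compound 4 (beyond the scatter) and is the one step here that clears the scatter. No evidence at hand explains either step.

From the compounds shown here alone, whether an amine or a carboxylic acid in that place on the ring would shift the number stays open. So does whether the naphthalen-1-yl step holds with nitro in place of fluoro.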